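The source may report more compounds than this note shows. Statements on the series, on what has been measured and on what is new or still open speak of the compounds shown alone.

Compound 2 `N#Cc1c(N)nc(NCCC2CCN(Cc3ccccc3)CC2)c(C#N)c1-c1ccccc1` in an ADME assay for permeability, using PAMPA, in phosphate buffer, with a stated time of 4 h, tested at 1 mg/mL (a lower number here means that the compound crosses the layer more slowly, a higher number that the compound crosses the layer faster), gives 34 10^-6 cm/s. Within the data shown here, the only other measured member, compound 1 `N#Cc1cc(C#N)c(NCCCCC2CCN(Cc3ccccc3)CC2)nc1N`, in this assay gives 21.2 10^-6 cm/s; the two numbers lie within the scatter of each other, so no order between compound 1 and compound 2 can be read from them. Among the measured compounds shown here, no pair of measured compounds that differ in a single place is available, so the size of a single structural change on this property has not yet been observed directly.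

Compound 3 `N#Cc1cc(C#N)c(NCCC2CCN(Cc3ccccc3)CC2)nc1N` has not been measured in this assay. It differs from compound 2 by hydrogen in place of phenyl on an aromatic carbon. Compound 3 thus carries the shared core of compound 1 and the linker of compound 2. Because compound 1 at 21.2 10^-6 cm/s and compound 2 at 34 10^-6 cm/s sit in a narrow band, the step of a 1.5-fold lower number from compound 2 to compound 3 (0.19 log units; within the scatter) is expected to be small, modestly downward and not clearly beyond the scatter. For compound 3 the estimate in this assay is 22 10^-6 cm/s, with a range from 11 10^-6 cm/s to 40 10^-6 cm/s.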

Compound 3, apparent permeability: 14.4 10^-6 cm/s
For compound 3 the middle estimate is 1.5-fold (0.18 log units) above the measured one, within the range that was stated.
By their numbers in this assay, from the lowest: compounds 3, 1 and 2 (each within the scatter of the next, the first and the last beyond it).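

In this assay, among these compounds, hydrogen in place of phenyl on the aromatic carbon opposite the ring nitrogen gives a 2.4-fold lower number from compound 2 to compound 3 (0.37 log units; beyond the scatter), the first change in a single place that the series offers. This position therefore has a readable effect on the number: the step lies beyond the scatter, though only modestly, whereas the earlier pair of compounds allowed no order at all. Nothing at hand gives a measured property that accounts for the direction or size of this step.

Going by these compounds, what remains open is whether the step belongs to phenyl as such or would follow any group on this carbon; a methyl, a methoxy or a pyridyl ring there would separate these cases, and would show whether the number climbs with the size of the group or depends on the aromatic ring. On these data alone, the step also rests on a single pair with one linker, so it is unknown whether phenyl at this position would shift the number by a similar amount on the linker of compound 1.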